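Cyclopropane acid in place of branched acid: an expectation

The source may report more compounds than this note shows. Statements on the series, on what has been measured and on what is new or still open speak of the compounds shown alone.

Compound 1 `Cc1nn(-c2ccccn2)c2cc(-c3ccc(CC(C)(C)C(=O)O)cc3)ccc12`: > 100000 nM
Compound 2 `Cc1nn(-c2ccccn2)c2cc(-c3ccc([C@H]4C[C@@H]4C(=O)O)cc3)ccc12`: > 100000 nM; > 100000 nM (2 entries)

In a functional assay on cells for agonist activity at Free fatty acid receptor 1 (Mus musculus), read by FLIPR and calcium flux, with a stated time of 5 min (on this read-out higher numbers stand for an effect only at larger amounts of compound and lower numbers for an effect already at smaller amounts), compound 1 gives no number at all. Compound 1 is reported only as a limit of the assay, > 100000 nM. It therefore sits at the limit of > 100000 nM in this assay, at which 1 of the 2 values shown sits. Compound 2 carries a 2-carboxycyclopropyl group on the shared core and is likewise reported only as a limit of the assay, > 100000 nM; > 100000 nM (2 entries), so neither measured compound shows an effect within the tested range.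

Compound 3 `Cc1nn(-c2ccccn2)c2cc(-c3ccc([C@@H]4C[C@H]4C(=O)O)cc3)ccc12` has not been measured. It differs from compound 1 by 2-carboxycyclopropyl in place of 2-carboxy-2-methylpropyl on an aromatic carbon. Within the data shown here, no step between measured compounds is available to guide the estimate, so the expectation rests on the shared silence of compound 1 and compound 2. The step from compound 1 to compound 3 is expected to be a number no higher from compound 1 to compound 3 (the limit leaves the size open), that is, none beyond the scatter. Compound 3 is therefore estimated at 100000 nM, within 20000 nM to 300000 nM, most likely again reported only as a limit.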

Compound 3, half-maximal effective concentration: > 100000 nM
Compound 3 gave a limit, no number; the forecaster's own chance of this, stated with the estimate: 75%; the middle value sits exactly at the limit.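

In this assay compound 3 is reported only as a limit, > 100000 nM. Compound 1 is also reported only as a limit, so no step can be read between compound 1 and compound 3. The compounds shown leave open whether the two cyclopropane acids differ in effect at all: the fact that compounds 2 and 3 differ only in the configuration as drawn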